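The source may hold more compounds than are shown below. What is called first, only, known or untested is meant among the compounds shown, and "the series" means these compounds.

Of the compounds shown here, three built on one shared core have been tested in a functional assay on HL-60 cells (Homo sapiens) for antiproliferative activity, with a stated time of 24 h; on this read-out lower numbers stand for stronger inhibition and higher numbers for weaker inhibition. Compound 1 `COc1ccccc1NC(=S)N1CCc2c(sc(NC(=O)c3ccccc3Cl)c2C(N)=O)C1` gives 40900 nM. Compound 2 `NC(=O)c1c(NC(=O)c2ccccc2I)sc2c1CCN(C(=S)Nc1ccccc1Cl)C2` gives 8560 nM. Compound 3 `NC(=O)c1c(NC(=O)c2ccccc2I)sc2c1CCN(C(=S)Nc1ccccc1C(F)(F)F)C2` gives 19700 nM, which places it second highest of the three numbers, with compound 2 lower and compound 1 higher. Compound 4 `COc1ccccc1NC(=S)N1CCc2c(sc(NC(=O)c3ccccc3I)c2C(N)=O)C1` has not yet been measured. Its difference from compound 3 is methoxy in place of trifluoromethyl on an aromatic carbon. Among the compounds with values here, one measured step concerns the same aromatic carbon: a 2.3-fold higher number from compound 2 to compound 3 (0.36 log units; beyond the scatter). Within the data shown here, that step swapped chloro for trifluoromethyl rather than trifluoromethyl for methoxy, so it shows only that a change here shifts the number by a modest amount. Among the measured compounds shown here, compound 1 also carries methoxy at this carbon, but it differs from compound 2 in two places, so their two values show only that compound 1 lies above compound 2. The step expected for compound 4 is a 1.3-fold higher number from compound 3 to compound 4 (0.10 log units; within the scatter), small and uncertain in direction. The estimate for compound 4 in this assay is 25000 nM, with a range from 9000 nM to 70000 nM.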

Compound 4, half-maximal inhibitory concentration: > 50000 nM
Compound 4 was reported as a limit; the forecaster's own chance of this, stated with the estimate: 10%; middle value at least 2.0-fold (0.30 log units) away from the limit.
By their numbers in this assay, from the lowest: compound 2; then compound 3; then compound 1. At a limit, above all of these: compound 4.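

In this assay, compound 4 is reported only as a limit, not as a number: the limit of > 50000 nM in this assay, at which 1 of the 4 values shown sits. Within the data shown here, with the rest of the molecule held constant, this aromatic carbon now carries three different groups, and methoxy gives the highest reading, with a 2.3-fold higher number from compound 2 to compound 3 (0.36 log units; beyond the scatter), an at least 2.5-fold higher number from compound 3 to compound 4 (0.40 log units; beyond the scatter) and an at least 5.8-fold higher number from compound 2 to compound 4 (0.76 log units; beyond the scatter), so chloro, trifluoromethyl and methoxy fall into a clear order, whereas the earlier compounds offered only one such swap. Iodo in place of chloro gives an at least 1.2-fold higher number from compound 1 to compound 4 (0.08 log units; that floor lies within the scatter), so this step cannot be read.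

The compounds shown leave open how far the number for compound 4 lies beyond its limit, and they give no reason for the order of the three groups. They also leave open how a hydroxyl group, an amine or a carboxylic acid on this same carbon would read.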